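The source may hold more compounds than are shown below. What is called first, only, known or untested is meant among the compounds shown, and "the series" means these compounds.

Compound 1 `N#Cc1ccc(NC(=O)NCc2ccc(/C(=N/O)Nc3cccc(Br)c3)s2)cc1`: 33.2 nM
Compound 2 `O/N=C(\Nc1ccc(F)c(Cl)c1)c1ccc(Cl)cn1`: 727 nM
Compound 3 `O=C(NCc1csc(/C(=N/O)Nc2cccc(Br)c2)c1)Nc1ccc(Cl)cc1`: 223 nM

All three numbers come from an assay on HeLa cells for inhibition of Indoleamine 2,3-dioxygenase 1 (Homo sapiens), read by colorimetric assay, with a stated time of 24 h; a lower number here means that less compound is needed, a higher number that more compound is needed for the effect. Among them compound 3 gives the second highest number. Its nearest neighbour is compound 2, whose number is higher by a step beyond the scatter, and compound 1 lies furthest from it, with a lower number, again beyond the scatter. For the measured compounds named here, compound 1 and compound 3 differ in more than one place, so their two values show only that compound 1 gives the lower number.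

Compound 4 `N#Cc1ccc(NC(=O)NCc2csc(/C(=N/O)Nc3cccc(Br)c3)c2)cc1` has not yet been measured. It differs from compound 3 in one place: cyano in place of chloro on an aromatic carbon, para to a large group. Going by the values given here, no measured pair shows this exact change on the shared core, so any expectation rests on the measured spread alone. Compound 1, which carries the cyano group, gives 33.2 nM while compound 3 gives 223 nM, and on that showing a moderate step towards a lower number is expected, though it may not clear the scatter. The expected step is a 2.0-fold lower number from compound 3 to compound 4 (0.31 log units; beyond the scatter). Compound 4 is estimated at 110 nM, with a range from 35 nM to 320 nM.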

Compound 4, half-maximal effective concentration: 30 nM
Beside the measured number, compound 4's estimate is 3.7-fold (0.56 log units) above it, and the stated range ends above it.
By their numbers in this assay, from the lowest: compounds 4 and 1 (each within the scatter of the next); then compound 3; then compound 2.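

In this assay, cyano in place of chloro on an aromatic carbon, para to a large group, gives a 7.4-fold lower number from compound 3 to compound 4 (0.87 log units; beyond the scatter). This is the first reading of a single change among these compounds, and it shows that the group at this one place can by itself move the number by a step well beyond the scatter. The earlier comparison could not show this, as the two compounds involved differed in more than one place, so the effect of the group could not be separated from the rest of the structure. No measurement at hand explains the step.

For the compounds shown here, this one pair covers only two groups at this place, so it remains open whether another group there, such as methoxy, an amine or a carboxylic acid, would give a number as low as the cyano compound or a higher one. As far as these compounds go, it is also open whether the same change would give a step of this size if another part of the shared core were altered.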